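The source may hold more compounds than are shown below. What is called first, only, known or untested is meant among the compounds shown, and "the series" means these compounds.

Measured compounds in an ADME assay on BHK cells (Mesocricetus auratus) for cytotoxicity, read by MTT assay, with a stated time of 96 h; on this read-out higher numbers stand for lower toxicity in this test and lower numbers for higher toxicity in this test:
- compound 1 `CCN(CC)CC(=O)Nc1ccc(-c2nc3cc(C(F)(F)F)ccc3n2C)cc1`: 16000 nM
- compound 2 `COc1ccc(-c2nc3cc(C(F)(F)F)ccc3[nH]2)cc1`: > 100000 nM
- compound 3 `O=C(CN1CCCC1)Nc1ccc(-c2nc3ccccc3[nH]2)cc1`: 55000 nM

Compound 2 gives no number in this assay but only a limit, > 100000 nM. That reading sits at the limit of > 100000 nM in this assay, at which 1 of the 3 values shown sits. Among the two numbers that were obtained, compound 3 holds the higher one in this assay, and its gap to compound 1 lies beyond the usual scatter of the test; compound 3 therefore stands as the less toxic of the two numbered compounds on this read-out.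

Compound 4 `O=C(CN1CCCCC1)Nc1ccc(-c2nc3ccccc3[nH]2)cc1` has not yet been measured. It differs from compound 3 in one place: piperidin-1-yl in place of pyrrolidin-1-yl on a saturated chain carbon bound to a carbonyl carbon. The shared core, the amide and the anilide part are unchanged.

For the measured compounds named here, no measured pair in this set differs by exactly such a change, so no measured step can be called on. The step from the five-membered to the six-membered saturated ring is small on a count of atoms, and the expectation is that a 1.2-fold lower number from compound 3 to compound 4 (0.09 log units; within the scatter) will be no larger than the scatter of repeated measurements in this assay, with no clear direction. On that basis compound 4 is estimated at 45000 nM, with a range from 20000 nM to 100000 nM.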

Compound 4, half-maximal cytotoxic concentration: 31000 nM
The estimate for compound 4 lay 1.5-fold (0.16 log units) above the measured number; the range from low to high includes it.
By their numbers in this assay, from the lowest: compounds 1, 4 and 3 (each within the scatter of the next, the first and the last beyond it). At a limit, above all of these: compound 2.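

In this assay, piperidin-1-yl in place of pyrrolidin-1-yl on a saturated chain carbon bound to a carbonyl carbon gives a 1.8-fold lower number from compound 3 to compound 4 (0.25 log units; within the scatter). For the compounds shown here, this is the first measured pair in the set that differs in one place only, and it shows that, with the shared core, the amide and the anilide part held constant, the five-membered and the six-membered ring cannot be told apart on this read-out, so that enlarging this saturated ring by one carbon leaves the number inside what repeated measurements would give. No measured information shown here offers a reason for this result.

The compounds shown leave open whether a morpholin-4-yl or a 4-methylpiperazin-1-yl group at the same place, or a longer chain between the carbonyl carbon and the ring, would stay within the scatter of compound 3 or move the number beyond it. They also leave open how far this tolerance extends to an open-chain amine, since compound 1 differs from compound 3 and compound 4 in more than one place and cannot settle that question.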